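From 4-fluorophenyl to 3-hydroxyphenyl on the shared core

This account rests on a few compounds, and the source may have more. Where it says the series, first, only, none or still open, it means among the compounds named here.

Within the data shown here, in a functional assay on MGC-803 cells (Homo sapiens) for inhibition, read by MTT assay, with a stated time of 72 h (on this read-out higher numbers stand for weaker inhibition and lower numbers for stronger inhibition), compound 1 `C#CCSc1nc(Nc2ccc(F)cc2)c2ccncc2n1` gives 15800 nM, the only true number so far. Compound 2 `C#CCSc1nc(Nc2ccc([N+](=O)[O-])cc2)c2ccncc2n1` gives no number here: its > 80000 nM is a limit. Compound 3 `C#CCSc1nc(Nc2cccc(O)c2)c2ccncc2n1` keeps the core of compound 1 and makes one change: 3-hydroxyphenyl in place of 4-fluorophenyl on a nitrogen on an aromatic ring. Among the measured compounds shown here, only one measured step also alters the 4-fluorophenyl: an at least 5.0-fold higher number from compound 1 to compound 2 (0.70 log units; beyond the scatter), with nitro in place of fluoro on an aromatic carbon. As far as these compounds go, that single step shows that this group can matter in this assay, but it involves a different change and its full size is unknown. The expected change is therefore small, a 1.3-fold higher number from compound 1 to compound 3 (0.10 log units; within the scatter), leaning slightly towards a higher number but staying within the scatter. Compound 3 is estimated at 20000 nM, with a plausible range of 6000 nM to 65000 nM.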

Compound 3, half-maximal inhibitory concentration: 15700 nM
Compound 3: middle estimate off by 1.3-fold (0.11 log units), on the high side; measured number inside the range.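

Within this assay the swap gives a 1.0-fold lower number from compound 1 to compound 3 (0.00 log units; within the scatter) and so shows that 3-hydroxyphenyl can take the place of 4-fluorophenyl on this nitrogen without moving the read-out beyond the scatter, even though it brings a hydrogen-bond donor and acceptor that 4-fluorophenyl lacks. Among these compounds, the earlier step of an at least 5.0-fold higher number from compound 1 to compound 2 (0.70 log units; beyond the scatter) showed only that a change on this aromatic ring can weaken inhibition, whereas compound 3 shows that not every change does. Nothing given here explains why compound 1 and compound 3 read alike.

As far as these compounds go, what an amine or a methoxy group on this ring would do remains open. So does whether any group at this place can bring the number clearly below that of compound 1.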